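Lengthening a hydroxy-bearing chain by one step

The compounds below may be only part of what the source reports. "The series", "measured", "known", "first", "only" and "open" are said of these compounds alone.

Compound 1 `CCCn1c(=O)n(C)c(=O)c2c1ncn2CC#N` gives 35300 nM
Compound 2 `CCCn1c(=O)n(C)c(=O)c2c1ncn2CCO` gives 31800 nM

Both values come from a functional assay (trachea) with Cavia porcellus as the target (a lower number here means that less compound is needed, a higher number that more compound is needed for the effect), and are the only two measured so far. Compound 2 therefore stands level with compound 1, inside the usual scatter. Compound 3 `CCCn1c(=O)n(C)c(=O)c2c1ncn2CCCO` is still unmeasured. It differs from compound 2 in one place: hydroxymethyl in place of hydroxy on a saturated chain carbon, two bonds along the chain from an aromatic nitrogen. Put another way, 2-hydroxyethyl becomes 3-hydroxypropyl. Within the data shown here, only one measured step bears on this: a 1.1-fold lower number from compound 1 to compound 2 (0.05 log units; within the scatter). That step swaps a group on a chain but does not lengthen one, so it is indirect evidence. Among the measured compounds shown here, no measured pair differs in chain length alone. The expected change is therefore small, with a 1.1-fold lower number from compound 2 to compound 3 (0.03 log units; within the scatter) as the estimate and nothing expected beyond the scatter. Compound 3 is expected at 30000 nM, with an estimated range from 13000 nM to 65000 nM in this measurement.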

Compound 3, half-maximal effective concentration: 22600 nM
Estimate against measurement, compound 3: 1.3-fold (0.12 log units) above; low and high end bracket the measured number.
By their numbers in this assay, from the lowest: compounds 3, 2 and 1 (each within the scatter of the next).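

Among these compounds, this is the first measured change in chain length at this position: in this assay, 3-hydroxypropyl in place of 2-hydroxyethyl gives a 1.4-fold lower number from compound 2 to compound 3 (0.15 log units; within the scatter), so the two compounds stand level. The nitrile-bearing chain and the longer hydroxy-bearing chain also stand level, with a 1.6-fold lower number from compound 1 to compound 3 (0.19 log units; within the scatter), so among these three compounds neither the change of end group nor the longer chain moves the number beyond the usual scatter. No measurement available here explains these numbers.

Going by these compounds, it remains open whether a longer chain, such as 4-hydroxybutyl, would move the number beyond the scatter. The same question stands for an amine or a carboxylic acid in place of the hydroxy group.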